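Swapping a Straight Ester Chain for a Ring

The source may report more compounds than this note shows. Statements on the series, on what has been measured and on what is new or still open speak of the compounds shown alone.

Measured so far:
compound 1, `CCCCCCOC(=O)c1cccc(-c2cc(C(=O)Nc3ccncc3)ccc2CN)c1`: 22 nM
compound 2, `CCCCCOC(=O)c1cccc(-c2cc(C(=O)Nc3ccncc3)ccc2CN)c1`: 4.9 nM

Both compounds share one core and differ only in the ester chain. Among the measured compounds shown here, in an assay on isolated protein for inhibition of Rho-associated protein kinase 2 (Homo sapiens), read by radiometric assay (a lower number here means a stronger inhibitor, a higher number a weaker inhibitor), compound 1 gives 22 nM, while compound 2 gives 4.9 nM, the lowest of the two numbers; the step of a 4.5-fold lower number from compound 1 to compound 2 (0.65 log units; beyond the scatter) is the only measured step available. Compound 3, `NCc1ccc(C(=O)Nc2ccncc2)cc1-c1cccc(C(=O)OCC2CCCC2)c1`, has not yet been measured. It differs from compound 2 in this way: cyclopentyl in place of butyl on a saturated chain carbon bound to an oxygen next to a carbonyl group. For the measured compounds named here, the one measured step, from a longer to a shorter straight chain at the same ester, lowered the number, so the size of this chain does shift the read-out. Going by the values given here, a ring closed at the end of the chain is a different kind of change, and no measured pair speaks to it directly, which leaves the direction open. The expectation for compound 3 is a step of a 1.6-fold higher number from compound 2 to compound 3 (0.21 log units; within the scatter), at most modest and possibly within the scatter. Compound 3 is therefore estimated at 8 nM, with a range from 3 nM to 25 nM.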

Compound 3, half-maximal inhibitory concentration: 5 nM
The estimate for compound 3 lay 1.6-fold (0.20 log units) above the measured number; low and high end bracket the measured number.
By their numbers in this assay, from the lowest: compounds 2 and 3 (each within the scatter of the next); then compound 1.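

In this assay, putting cyclopentyl in place of butyl on a saturated chain carbon bound to an oxygen next to a carbonyl group gives a 1.0-fold higher number from compound 2 to compound 3 (0.01 log units; within the scatter), so a closed ring at the end of this chain fits as well as the open chain of compound 2. Cyclopentyl in place of pentyl gives a 4.4-fold lower number from compound 1 to compound 3 (0.64 log units; beyond the scatter), which shows that the ring form of this group does not carry the higher number seen with the longest open chain. Among these three compounds, then, the read-out at this place depends on the shape of the group and not only on how many carbons it holds, though no measurement shown here offers an explanation for this.

Going by these compounds, whether the same holds for a smaller ring such as cyclopropyl or a larger one such as cyclohexyl remains open, and so does the effect of a shorter straight chain such as propyl. It is also unknown how the number would respond to a ring containing oxygen, such as tetrahydropyranyl, or to an amine at the end of the chain.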